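Shortening the Propoxy Chain on the Core of Compound 3

A few compounds are considered here, and "the series" means these few. Any claim that something is new, unique, unknown or untested is made for them only; others in the source may bear on it.

Compound 1 `CCc1ccc(-c2cc(Cl)cc(C(=O)Nc3nn[nH]n3)n2)cc1` gives 49% in a functional assay on the whole organism with Rattus norvegicus as the target, at a dose of 1 mg/kg by the oral route; on this read-out lower numbers stand for a weaker effect and higher numbers for a stronger effect at the one dose given.
Compound 2 `CCCCc1ccc(-c2cc(Cl)cc(C(=O)Nc3nn[nH]n3)n2)cc1` gives 0% in this assay.
Compound 3 `CCCOc1cc(C(=O)Nc2nn[nH]n2)nc(-c2ccc(N)cc2)c1` gives 64% in this assay.

Compound 3 thus stands highest of the three, beyond the scatter from compound 1 and from compound 2. Compound 4 `Cc1cc(C(=O)Nc2nn[nH]n2)nc(-c2ccc(N)cc2)c1` differs from compound 3 by methyl in place of propoxy on an aromatic carbon, on an aromatic carbon of a six-membered aromatic ring with 1 nitrogen, opposite the ring nitrogen. Among the compounds with values here, the only measured step, a number 49 percentage points lower from compound 1 to compound 2 (beyond the scatter), concerns ethyl in place of hydrogen on a saturated chain carbon two bonds along the chain from an aromatic carbon: a different place and a lengthening, not a shortening. It shows that chain changes can move the read-out strongly, but gives no direction here. Compound 4 is therefore expected to give 52% (20% to 78%) in this assay. The expected step is a number 12 percentage points lower from compound 3 to compound 4 (beyond the scatter), a moderate, uncertain decrease.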

Compound 4, a percentage reported as inhibition, in the whole organism at one dose (the size of the read-out at that dose, not a potency): 75%
Compound 4: the middle estimate sits 23 percentage points below what was measured, and the stated range covers the measured number.
By their numbers in this assay, from the lowest: compound 2; then compound 1; then compound 3; then compound 4.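

Opposite the ring nitrogen on the core, methyl in place of propoxy gives a number 11 percentage points higher from compound 3 to compound 4 (beyond the scatter) in this assay and so the propoxy chain is not required for the effect at this dose. Within the data shown here, this is the first measured step at this position, and it runs upward on shortening, while the only earlier step concerned a different chain and a lengthening. No measurement at hand accounts for the gain.

As far as these compounds go, whether ethoxy, a hydroxy group or an amine on this carbon would keep or raise the read-out stays open. Two groups at one position also define no trend with chain length.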